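A few compounds are considered here, and "the series" means these few. Any claim that something is new, unique, unknown or untested is made for them only; others in the source may bear on it.

Measured so far:
- compound 1 `Oc1cccc(-c2cc(-c3cccc(O)c3)nc(-c3ccccc3O)c2)c1`: 50000 nM
- compound 2 `Oc1ccc(-c2cc(-c3cccc(O)c3)cc(-c3cccc(O)c3)n2)cc1`: 3920 nM
- compound 3 `Oc1ccc(-c2cc(-c3ccccc3O)cc(-c3ccccc3O)n2)cc1`: 960 nM

In a functional assay on T47D cells (Homo sapiens) for cytotoxicity, read by CCK-8 assay, with a stated time of 4 days (on this read-out lower numbers stand for stronger inhibition and higher numbers for weaker inhibition), compound 1 gives 50000 nM. One change, (4-hydroxyphenyl in place of 2-hydroxyphenyl on an aromatic carbon), produced a 13-fold lower number from compound 1 to compound 2 (1.11 log units; beyond the scatter). Compound 3 gives 960 nM, below compound 2; the difference between the cores of compound 1 and compound 3 is not broken down here.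

Compound 4 `Oc1ccc(-c2cc(-c3ccccc3O)cc(-c3ccc(O)cc3)n2)cc1` is unmeasured. It differs from compound 3 by 4-hydroxyphenyl in place of 2-hydroxyphenyl on an aromatic carbon, the same kind of change as from compound 1 to compound 2, though the surroundings differ: there the place was meta to two 3-hydroxyphenyl groups, here it is meta to a 2-hydroxyphenyl group and a 4-hydroxyphenyl group. A lowering is expected for compound 4, estimated as a 3.2-fold lower number from compound 3 to compound 4 (0.51 log units; beyond the scatter), smaller than the earlier step because compound 3 already gives 960 nM. Compound 4 is estimated at 300 nM, expected between 80 nM and 1500 nM.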

Compound 4, half-maximal inhibitory concentration: 5350 nM
Compound 4: middle estimate off by 18-fold (1.25 log units), on the low side; measured number outside the range, above it.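

In this assay, 4-hydroxyphenyl in place of 2-hydroxyphenyl gives a 5.6-fold higher number from compound 3 to compound 4 (0.75 log units; beyond the scatter) in this pair. The change therefore does not carry over from one core to the other, since the two steps run in opposite directions: the same change on two cores in this assay, a 13-fold lower number (1.11 log units; beyond the scatter) from compound 1 to compound 2 and a 5.6-fold higher number (0.75 log units; beyond the scatter) from compound 3 to compound 4, 71-fold (1.85 log units) apart, beyond the scatter of two such steps

Within the data shown here, with only two pairs, this shows that the outcome of the change depends on its surroundings in these compounds, but it does not show which difference between the cores is responsible, nor does it give a rule for any other core.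

All compounds shown carry only hydroxyphenyl groups, so the effect of replacing a hydroxyl with a methoxy group, an amine or a carboxylic acid remains open. Also open, as far as these compounds go, is how this change would behave with such groups elsewhere on the core.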